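Moving the acid out along the chain from the piperidine nitrogen

A few compounds are considered here, and "the series" means these few. Any claim that something is new, unique, unknown or untested is made for them only; others in the source may bear on it.

Compound 1 `CCCN1CCC(CCCn2c(COc3ccc(Cl)cc3)nc3c(C)cccc32)CC1`: 29 nM
Compound 2 `CCOC(=O)CCCN1CCC(CCCn2c(COc3ccc(Cl)cc3)nc3c(C)cccc32)CC1`: 29 nM
Compound 3 `Cc1cccc2c1nc(COc1ccc(Cl)cc1)n2CCCC1CCN(CC(=O)O)CC1`: 2190 nM

In an assay on AV12 cells for binding affinity to Neuropeptide Y receptor type 1 (Homo sapiens) (on this read-out lower numbers stand for stronger inhibition and higher numbers for weaker inhibition), compound 3 gives the highest number of the three, far from compound 1 and compound 2, which stand together. Compound 4 `Cc1cccc2c1nc(COc1ccc(Cl)cc1)n2CCCC1CCN(CCCC(=O)O)CC1` differs from compound 3 by 2-carboxyethyl in place of carboxy on a saturated chain carbon bound to an amine nitrogen in a ring. Among the measured compounds shown here, two measured steps bear on this. The step of a 76-fold higher number from compound 1 to compound 3 (1.88 log units; beyond the scatter) shows that placing the acid right on the carbon bound to the ring nitrogen costs much. The step of no change at the digits printed from compound 1 to compound 2 (within the scatter) shows that a chain of the same length carrying an ester instead of hydrogen changes nothing within the scatter. Compound 4 carries its acid on that longer chain, so the step of a 37-fold lower number from compound 3 to compound 4 (1.56 log units; beyond the scatter) is expected to be a large improvement. Compound 4 is estimated at 60 nM, within 15 nM to 300 nM.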

Compound 4, inhibition constant: 1630 nM
The estimate for compound 4 lay 27-fold (1.43 log units) below the measured number, and the stated range ends below it.
By their numbers in this assay, from the lowest: compounds 1 and 2 (each within the scatter of the next); then compounds 4 and 3 (each within the scatter of the next).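

Lengthening the chain does not rescue the acid: a 1.3-fold lower number from compound 3 to compound 4 (0.13 log units; within the scatter) stays within the scatter, so carboxy and 2-carboxyethyl cannot be told apart on this position. The large loss follows the free acid instead, since hydrogen in place of the ester's ethyl gives a 56-fold higher number from compound 2 to compound 4 (1.75 log units; beyond the scatter), and carboxy in place of hydrogen on the chain gives a 56-fold higher number from compound 1 to compound 4 (1.75 log units; beyond the scatter). No measurement available here explains why the ester and the acid differ so much. Open, going by these compounds, is whether a primary amide or an amine on this chain would track the ester or the acid.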